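A few compounds are considered here, and "the series" means these few. Any claim that something is new, unique, unknown or untested is made for them only; others in the source may bear on it.

The measured compounds:

Compound 1 `O=C(Nc1c(F)cc(F)cc1F)N(Cc1ccc(-c2cccs2)cc1)C1CCCCCC1`, in an assay on microsomes from intestine for inhibition of acyl-CoA:cholesterol acyltransferase (Oryctolagus cuniculus) (on this read-out lower numbers stand for stronger inhibition and higher numbers for weaker inhibition), compound 1 gives 18 nM.
Compound 2 `Cc1cc(C)c(NC(=O)N(Cc2ccc(-c3cccs3)cc2)C2CCCCCC2)c(C)c1`, in this assay compound 2 gives 22 nM.
Compound 3 `O=C(Nc1c(F)cc(F)cc1F)N(Cc1ccc(-n2cccc2)cc1)C1CCCCCC1`, in this assay compound 3 gives 27 nM.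

Compound 2 sits second highest of the three numbers, yet its neighbours are close: the step of a 1.2-fold higher number from compound 1 to compound 2 (0.09 log units; within the scatter) lies within the scatter, and its value and that of compound 3 also lie within the scatter of each other. Compound 4 `Cc1cc(C)c(NC(=O)N(Cc2ccc(-n3cncn3)cc2)C2CCCCCC2)c(C)c1` has not yet been measured. It differs from compound 2 in one place: 1H-1,2,4-triazol-1-yl in place of thiophen-2-yl on an aromatic carbon. The step that bears on this is a 1.5-fold higher number from compound 1 to compound 3 (0.18 log units; within the scatter), where a different five-membered ring took the place of thiophen-2-yl on the same aromatic carbon, and the number stayed within the scatter. On that basis the exchange of thiophen-2-yl for a five-membered ring with more hetero atoms is expected to give at most a modest shift, if any, in this assay, leaning toward a slightly higher number. The expected step is a 1.8-fold higher number from compound 2 to compound 4 (0.26 log units; within the scatter). Compound 4 is therefore estimated at 40 nM, within a range from 15 nM to 110 nM.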

Compound 4, half-maximal inhibitory concentration: 26 nM
Compound 4: middle estimate off by 1.5-fold (0.19 log units), on the high side, and the stated range covers the measured number.
By their numbers in this assay, from the lowest: compounds 1, 2, 4 and 3 (each within the scatter of the next).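

In this assay, 1H-1,2,4-triazol-1-yl in place of thiophen-2-yl gives a 1.2-fold higher number from compound 2 to compound 4 (0.07 log units; within the scatter) on this aromatic carbon, para to a large group. The earlier exchange for 1H-pyrrol-1-yl, a 1.5-fold higher number from compound 1 to compound 3 (0.18 log units; within the scatter) with 2,4,6-trifluorophenyl on the amide-type nitrogen, did not show that a ring with 3 hetero atoms and 3 hydrogen-bond acceptors also stays within the scatter here, now with 2,4,6-trimethylphenyl on that nitrogen. No measurement shown explains why the number holds across this exchange.

The compounds shown leave open whether an amine, a carboxylic acid, a longer alkyl chain or a pyridin-3-yl ring at this position would also stay within the scatter. They also leave open how 1H-1,2,4-triazol-1-yl behaves with 2,4,6-trifluorophenyl on the amide-type nitrogen.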